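This account rests on a few compounds, and the source may have more. Where it says the series, first, only, none or still open, it means among the compounds named here.

In a functional assay on MV4-11 cells (Homo sapiens) for antiproliferative activity, read by luminescence and CellTiter-Glo, with a stated time of 72 h (on this read-out higher numbers stand for weaker inhibition and lower numbers for stronger inhibition), compound 1 `Cc1noc(C)c1-c1ccc2c(Nc3ccc(F)cc3)nn(C3CCCCO3)c2c1` gives 9900 nM and compound 2 `CNc1cc(-c2ccc3cnn(Cc4ccc(F)cc4)c3c2)cn(C)c1=O` gives 2390 nM while compound 3 `CNc1cc(-c2ccc3cnn(Cc4ccc(C)cc4)c3c2)cn(C)c1=O` gives 3280 nM on the same scale. Compound 3 thus cannot be told apart from compound 2, and its number is clearly lower than that of compound 1. Compound 4 `CNc1cc(-c2ccc3cnn(Cc4ccc(F)c(F)c4)c3c2)cn(C)c1=O` has 3,4-difluorophenyl in place of 4-methylphenyl on a saturated chain carbon bound to an aromatic nitrogen and is otherwise unchanged. Among the compounds with values here, only one measured step bears on this change: a 1.4-fold higher number from compound 2 to compound 3 (0.14 log units; within the scatter) with methyl in place of fluoro on an aromatic carbon. That step was small, so no step beyond the scatter is expected in this assay for this change. The expected step is a 1.3-fold lower number from compound 3 to compound 4 (0.10 log units; within the scatter) and would be a slightly lower number at most. For compound 4 the estimated value is 2600 nM with an expected range from 1300 nM to 5200 nM in this measurement.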

Compound 4, half-maximal inhibitory concentration: 320 nM
Beside the measured number, compound 4's estimate is 8.1-fold (0.91 log units) above it; measured number below the stated range.
By their numbers in this assay, from the lowest: compound 4; then compounds 2 and 3 (each within the scatter of the next); then compound 1.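

Changing 4-methylbenzyl to 3,4-difluorobenzyl gives a 10-fold lower number from compound 3 to compound 4 (1.01 log units; beyond the scatter) in this assay and shows that this position can respond strongly, which the earlier methyl and fluoro pair did not reveal. Fluoro in place of hydrogen on an aromatic carbon alone gives a 7.5-fold lower number from compound 2 to compound 4 (0.87 log units; beyond the scatter) on the same read-out, so a single added fluoro is enough to move the number beyond the scatter. No measurement shown here explains this gain. Going by these compounds, whether chloro, methoxy or nitrile on this ring would match the second fluoro remains open, as does the effect of a longer chain in place of the benzyl link.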